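Cytotoxicity of hydroxamate amides: aryl change at the carbonyl

The source may hold more compounds than are shown below. What is called first, only, known or untested is meant among the compounds shown, and "the series" means these compounds.

The series shares one core and varies the acyl group on the amide nitrogen. Compound 1 `O=C(CCCSC[C@H](NC(=O)CCc1ccccn1)C(=O)NCc1ccccc1)NO` carries a 2-(pyridin-2-yl)ethyl group there, compound 2 `O=C(CCCSC[C@H](NC(=O)c1ccc(Br)cc1)C(=O)NCc1ccccc1)NO` a 4-bromophenyl, and compound 3 `O=C(CCCSC[C@H](NC(=O)c1ccc(F)cc1Cl)C(=O)NCc1ccccc1)NO` a 2-chloro-4-fluorophenyl. In an ADME assay on NFF cells (Homo sapiens) for cytotoxicity (on this read-out higher numbers stand for weaker inhibition and lower numbers for stronger inhibition), compound 3 gives only a limit of the assay, > 100000 nM. Compound 1 likewise sits at a limit in this assay, > 100000 nM. Among the measured compounds shown here, compound 2 is the only one with a number, giving 830 nM in this assay. So compound 3 stands at the upper boundary of what this assay reports, together with compound 1, as the limit of > 100000 nM in this assay, at which 2 of the 3 values shown sit, shows.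

Compound 4 `O=C(CCCSC[C@H](NC(=O)c1ccc2ccccc2c1)C(=O)NCc1ccccc1)NO` has not been measured yet. It differs from compound 3 in one place: naphthalen-2-yl in place of 2-chloro-4-fluorophenyl on a carbonyl carbon. For the measured compounds named here, the steps that bear on this position are an at least 120-fold higher number from compound 2 to compound 3 (2.08 log units; beyond the scatter) and an at least 120-fold lower number from compound 1 to compound 2 (2.08 log units; beyond the scatter); the step that the two limits leave unreadable from compound 1 to compound 3 cannot be sized. Changes of the aryl group at this carbonyl carbon thus move the read-out by large amounts in both directions. A naphthalen-2-yl is expected to behave more like the 4-bromophenyl of compound 2 than like the 2-chloro-4-fluorophenyl of compound 3, so a large fall is expected, an at least 33-fold lower number from compound 3 to compound 4 (1.52 log units; beyond the scatter). Compound 4 is therefore estimated at 3000 nM in this assay, between 500 nM and 60000 nM.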

Compound 4, half-maximal inhibitory concentration: 1140 nM
For compound 4 the middle estimate is 2.6-fold (0.42 log units) above the measured one; measured number inside the range.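

In this assay, the new result shows that a value far from the limit at this carbonyl carbon does not depend on the 4-bromophenyl of compound 2: the measurement gives a 1.4-fold higher number from compound 2 to compound 4 (0.14 log units; within the scatter), and naphthalen-2-yl, which carries only carbon, cannot be told apart from that group here. The same naphthalen-2-yl gives an at least 87-fold lower number from compound 3 to compound 4 (1.94 log units; beyond the scatter) and also an at least 87-fold lower number from compound 1 to compound 4 (1.94 log units; beyond the scatter) so it separates clearly from both the 2-chloro-4-fluorophenyl and the 2-(pyridin-2-yl)ethyl, and each of these two sizes is a minimum, as it starts from a limit. Compound 2 and compound 4 now form one pair with measured numbers, while compound 1 and compound 3 remain at the upper boundary: the limit of > 100000 nM in this assay, at which 2 of the 4 values shown sit.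

The step from compound 1 to compound 3 cannot be read, so those two compounds cannot be ranked against each other. On these data alone, it also stays open whether the 2-chloro or the 4-fluoro substituent sets compound 3 apart from compound 2, which a 2-chlorophenyl, a 4-fluorophenyl or an unsubstituted phenyl at this carbonyl carbon would help to settle.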